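Five-membered ring swaps on the chlorophenyl arm

A few compounds are considered here, and "the series" means these few. Any claim that something is new, unique, unknown or untested is made for them only; others in the source may bear on it.

Measured compounds:
compound 1 `Cn1nc2c(=O)n(CC3(O)CCN(Cc4ccc(-c5ccncc5)cc4Cl)CC3)cnc2c1-c1ccc(CN)cc1`; in an assay on isolated protein for inhibition of ubiquitin carboxyl-terminal hydrolase 7 (Homo sapiens), with stated times of 30 min and 2 h (a lower number here means a stronger inhibitor, a higher number a weaker inhibitor), compound 1 gives 257 nM
compound 2 `Cn1nc2c(=O)n(CC3(O)CCN(Cc4ccc(-c5ccoc5)cc4Cl)CC3)cnc2c1-c1ccc(CN)cc1`; in this assay compound 2 gives 177 nM

Among the measured compounds shown here, compound 2 holds the smaller of the two numbers, but the single step that separates it from compound 1 is small: a 1.5-fold lower number from compound 1 to compound 2 (0.16 log units; within the scatter). The two values therefore show no difference that can be trusted.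

Compound 3 `Cn1nc2c(=O)n(CC3(O)CCN(Cc4ccc(-n5cccn5)cc4Cl)CC3)cnc2c1-c1ccc(CN)cc1` differs from compound 2 in one place: 1H-pyrazol-1-yl in place of furan-3-yl on an aromatic carbon. For the measured compounds named here, the only measured step that bears on this change is the earlier ring exchange at the same place, a 1.5-fold lower number from compound 1 to compound 2 (0.16 log units; within the scatter), and that step stayed within the scatter. With no measured step beyond the scatter at this position, compound 3 is expected to give a number close to that of compound 2, with a 1.2-fold higher number from compound 2 to compound 3 (0.07 log units; within the scatter) as the estimated step. Compound 3 is therefore estimated at 210 nM, with a likely range from 100 nM to 450 nM.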

Compound 3, half-maximal inhibitory concentration: 233 nM
Compound 3: middle estimate off by 1.1-fold (0.05 log units), on the low side, and the stated range covers the measured number.
By their numbers in this assay, from the lowest: compounds 2, 3 and 1 (each within the scatter of the next).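

With compound 3, this position, meta to a chloro group, has carried three different aromatic rings, and in this assay the numbers do not separate: the steps are (a 1.3-fold higher number from compound 2 to compound 3 (0.12 log units; within the scatter)) and (a 1.1-fold lower number from compound 1 to compound 3 (0.04 log units; within the scatter)), so all three compounds lie within the scatter of one another. Neither furan-3-yl nor pyridin-4-yl can be told apart from 1H-pyrazol-1-yl here, even though the five-membered aromatic ring now holds 2 hetero atoms rather than 1. No measurement is available that would explain this flat result.

As far as these compounds go, whether the position stays as flat once the aromatic ring is gone remains open: a morpholine, a carboxylic acid or a longer alkyl chain there could give a step beyond the scatter or none. The compounds also leave open whether this flat response holds when another part of the structure is changed.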